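The compounds below may be only part of what the source reports. "The series", "measured", "known", "first", "only" and "open" are said of these compounds alone.

Measured compounds:
compound 1 `Cn1ncc2cc(-c3cnc4[nH]ccc4c3N3CCC4(CCNC4=O)CC3)ccc21` gives 7 nM
compound 2 `Cn1cnc2ccc(-c3cnc4[nH]ccc4c3N3CCC4(CCNC4=O)CC3)cc21` gives 11 nM
compound 3 `Cn1cnc2cc(-c3cnc4[nH]ccc4c3N3CCC4(CCNC4=O)CC3)ccc21` gives 50 nM

These three compounds share one core and differ only in the aryl group attached to it, and all were tested in an assay on cells for binding affinity to Cyclin-C/Cyclin-dependent kinase 19 (Homo sapiens), read by LanthaScreen; a lower number here means a stronger inhibitor, a higher number a weaker inhibitor. Compound 1 has the lowest number of the three, but compound 2 sits close, the step of a 1.6-fold higher number from compound 1 to compound 2 (0.20 log units; within the scatter) being within the scatter, so no order between them can be claimed. Compound 3 stands further off: a 7.1-fold higher number from compound 1 to compound 3 (0.85 log units; beyond the scatter) and a 4.5-fold higher number from compound 2 to compound 3 (0.66 log units; beyond the scatter).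

Compound 4 `O=C1NCCC12CCN(c1c(-c3ccc4[nH]cnc4c3)cnc3[nH]ccc13)CC2` has not yet been measured. Relative to compound 1 the change is 1H-benzimidazol-5-yl in place of 1-methyl-1H-indazol-5-yl on an aromatic carbon. Both measured steps from compound 1 bear on this: the step to compound 2 cost little, while the step to compound 3 cost a modest amount. 1H-benzimidazol-5-yl carries no methyl group. It resembles both 1-methyl-1H-benzimidazol-6-yl and 1-methyl-1H-benzimidazol-5-yl, and an intermediate outcome, a modest rise beyond the scatter, is expected. The estimated step is a 2.9-fold higher number from compound 1 to compound 4 (0.46 log units; beyond the scatter). Compound 4 is estimated at 20 nM, with a range from 7 nM to 60 nM.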

Compound 4, half-maximal inhibitory concentration: 17 nM
Estimate against measurement, compound 4: 1.2-fold (0.07 log units) above; the measured number falls inside the stated range.
By their numbers in this assay, from the lowest: compounds 1, 2 and 4 (each within the scatter of the next, the first and the last beyond it); then compound 3.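

In this assay, for the compounds shown here, hydrogen in place of methyl on the aromatic nitrogen gives a 2.9-fold lower number from compound 3 to compound 4 (0.47 log units; beyond the scatter) and so reads the effect of that methyl alone, which the earlier compounds could not do. The 1H-benzimidazol-5-yl group remains apart from 1-methyl-1H-indazol-5-yl, with a 2.4-fold higher number from compound 1 to compound 4 (0.39 log units; beyond the scatter) as the printed step, while a 1.5-fold higher number from compound 2 to compound 4 (0.19 log units; within the scatter) allows no order against 1-methyl-1H-benzimidazol-6-yl. Nothing measured here explains why removing the methyl changes the number.

Going by these compounds, it remains open whether the gain depends on the hydrogen on that nitrogen or simply on the absence of methyl, and an ethyl or a 2-methoxyethyl chain there would extend the comparison. On these data alone, how 1H-indazol-5-yl would compare with 1-methyl-1H-indazol-5-yl at this position on the shared core also remains open.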